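Methyl on the phenolic oxygen: cytotoxicity on Vero cells

The source may hold more compounds than are shown below. What is called first, only, known or untested is meant among the compounds shown, and "the series" means these compounds.

The series shares a core carrying a sulfonamide-bearing aryl ring, seen in compound 1 `COc1ccc(C2=NN(c3ccc(S(N)(=O)=O)cc3)C(c3cn(-c4ccccc4)nc3-c3ccccc3)C2)cc1`, compound 2 `NS(=O)(=O)c1ccc(N2N=C(c3ccc(Br)cc3)CC2c2cn(-c3ccccc3)nc2-c2ccc(F)cc2)cc1`, and compound 3 `NS(=O)(=O)c1ccc(N2N=C(c3ccc(O)cc3)CC2c2cn(-c3ccccc3)nc2-c2ccc(F)cc2)cc1`. In an ADME assay on Vero cells (Chlorocebus sabaeus) for cytotoxicity, read by MTT assay, with a stated time of 72 h (on this read-out higher numbers stand for lower toxicity in this test and lower numbers for higher toxicity in this test), compound 1 gives 40200 nM, compound 2 gives 49400 nM, and compound 3 gives 32000 nM. Compound 3 thus shows the lowest of the three numbers, but every gap to the others lies within the scatter. Within the data shown here, the only single-point step in this set, from compound 2 to compound 3, is a 1.5-fold lower number from compound 2 to compound 3 (0.19 log units; within the scatter), and so carries no real signal.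

Compound 4 `COc1ccc(C2=NN(c3ccc(S(N)(=O)=O)cc3)C(c3cn(-c4ccccc4)nc3-c3ccc(F)cc3)C2)cc1` differs from compound 3 by methyl in place of hydrogen on an oxygen on an aromatic ring. Among the measured compounds shown here, no measured step addresses this change directly; the closest reference is compound 1, which already carries the methoxy group and whose value sits within the scatter of compound 3. For the measured compounds named here, all steps so far are within the scatter, so no shift beyond the scatter is expected for compound 4 in this assay, an estimated step of a 1.3-fold higher number from compound 3 to compound 4 (0.10 log units; within the scatter). Compound 4 is therefore expected to give about 40000 nM, with a likely range from 20000 nM to 80000 nM.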

Compound 4, half-maximal cytotoxic concentration: > 53100 nM
Compound 4 ended at the assay's limit; the forecaster's own chance of this, stated with the estimate: 10%; at least 1.3-fold (0.12 log units) between middle value and limit.
By their numbers in this assay, from the lowest: compounds 3, 1 and 2 (each within the scatter of the next). At a limit, above all of these: compound 4.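

In this assay compound 4 stands at a limit of the assay and not at a number: the limit of > 53100 nM in this assay, at which 1 of the 4 values shown sits. Methyl in place of hydrogen on the oxygen gives an at least 1.6-fold higher number from compound 3 to compound 4 (0.21 log units; that floor lies within the scatter), while methoxy in place of bromo gives an at least 1.0-fold higher number from compound 2 to compound 4 (0.03 log units; that floor lies within the scatter), and fluoro in place of hydrogen gives an at least 1.3-fold higher number from compound 1 to compound 4 (0.12 log units; that floor lies within the scatter). Among these compounds, the earlier compounds all gave numbers, whereas here the read-out runs out for the first time, and since each of these floors lies within the scatter, the steps point to no lower number for compound 4 but do not establish a shift beyond the scatter.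

On these data alone, how far compound 4 lies past the limit remains open, and with it the true size of all three steps. Also open, as far as these compounds go, is whether an ethyl group on this oxygen, or an amine in place of the methoxy, would give a number or reach the same limit.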